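A few compounds are considered here, and "the series" means these few. Any claim that something is new, unique, unknown or untested is made for them only; others in the source may bear on it.

Measured compounds:
Compound 1, `C[C@]1(CO)OC[C@@H](n2cc(F)c(N)nc2=O)O1`, gives 50000 nM in a functional assay on P388 cells (Mus musculus) for inhibition; on this read-out lower numbers stand for stronger inhibition and higher numbers for weaker inhibition.
Compound 2, `C[C@]1(CO)OCC(n2ccc(N)nc2=O)O1`, gives > 100000 nM in this assay, which is a limit of the assay and not a number.

Compound 2 therefore stands at the edge of what this assay reports: its value is the limit of > 100000 nM in this assay, at which 1 of the 2 values shown sits. Going by the values given here, compound 1 is the only compound here with a numerical value, and it is a weak inhibitor as well.

Compound 3, `C[C@]1(CO)OCC(n2cc(F)c(N)nc2=O)O1`, differs from compound 2 by fluoro in place of hydrogen on an aromatic carbon. Among the compounds with values here, no step between two measured compounds runs this way, so the size of the expected change rests on compound 1, which carries the same fluoro group and gives 50000 nM in this assay. The change is expected to bring an at least 1.4-fold lower number from compound 2 to compound 3 (0.15 log units; that floor lies within the scatter), a modest strengthening at most, since compound 2 is known only by a limit. Compound 3 is estimated at 70000 nM, between 20000 nM and 200000 nM.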

Compound 3, half-maximal inhibitory concentration: > 100000 nM
Compound 3 was reported as a limit; the forecaster's own chance of this, stated with the estimate: 45%; middle value at least 1.4-fold (0.15 log units) away from the limit.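

In this assay compound 3 gives > 100000 nM, which is a limit of the assay and not a number, so fluoro on this aromatic carbon, ortho to the amino group, does not bring the compound off the limit where compound 2 also stands: the limit of > 100000 nM in this assay, at which 2 of the 3 values shown sit. The step between those two limits cannot be read, so any effect of this change remains without a size. The one readable comparison is an at least 2.0-fold higher number from compound 1 to compound 3 (0.30 log units; that floor lies within the scatter), a floor that does not by itself go beyond the scatter, and it concerns only how one stereocentre is drawn: the fact that one of compounds 1 and 3 is drawn with a defined configuration and the other without, at the place where they differ

Going by these compounds, how far compound 2 and compound 3 actually lie past the limit stays open. So does whether chloro or methyl on this aromatic carbon would give a number inside the range of this assay.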